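Bromophenyl ketone on a bromoindole core: expected growth inhibition

The compounds below may be only part of what the source reports. "The series", "measured", "known", "first", "only" and "open" are said of these compounds alone.

Measured compounds:
compound 1 `COc1ccc(C(=O)n2c(-c3cn(C)c4ccccc34)nc3ccccc32)cc1OC` with 10200 nM
compound 2 `Cn1cc(-c2nc3ccccc3n2C(=O)c2ccccc2Br)c2ccccc21` with 70100 nM
compound 3 `COc1ccc(C(=O)n2c(-c3cn(C)c4ccc(Br)cc34)nc3ccccc32)cc1OC` with 11300 nM

In a functional assay on MCF7 cells (Homo sapiens) for inhibition, read by MTT assay, with a stated time of 24 h (a higher number here means a weaker inhibitor of growth, a lower number a stronger inhibitor of growth), the three measured compounds spread widely. The change 2-bromophenyl in place of 3,4-dimethoxyphenyl on a carbonyl carbon gave a 6.9-fold higher number from compound 1 to compound 2 (0.84 log units; beyond the scatter). The cores of compound 1 and compound 3 differ by bromo in place of hydrogen on an aromatic carbon, which gave a 1.1-fold higher number from compound 1 to compound 3 (0.04 log units; within the scatter). Compound 4 `Cn1cc(-c2nc3ccccc3n2C(=O)c2ccccc2Br)c2cc(Br)ccc21` is not yet measured; it carries the change (2-bromophenyl in place of 3,4-dimethoxyphenyl on a carbonyl carbon), the same change as the one measured, on the same place. Its step in this assay is therefore expected to be of about the same size as the measured one, resting on one pair only, so that the expected step from compound 3 to compound 4 is a 6.6-fold higher number from compound 3 to compound 4 (0.82 log units; beyond the scatter). Compound 4 is thus estimated to give about 75000 nM, with the range 30000 nM to 180000 nM.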

Compound 4, concentration for 50% growth inhibition: 73600 nM
Beside the measured number, compound 4's estimate is 1.0-fold (0.01 log units) above it, within the range that was stated.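

In this assay, 2-bromophenyl in place of 3,4-dimethoxyphenyl on a carbonyl carbon gave a 6.5-fold higher number from compound 3 to compound 4 (0.81 log units; beyond the scatter), and this step carried from one core to the other: the same change on two cores in this assay, a 6.9-fold higher number (0.84 log units; beyond the scatter) from compound 1 to compound 2 and a 6.5-fold higher number (0.81 log units; beyond the scatter) from compound 3 to compound 4, 1.1-fold (0.02 log units) apart, within the scatter of two such steps

Bromo in place of hydrogen on an aromatic carbon gave a 1.0-fold higher number from compound 2 to compound 4 (0.02 log units; within the scatter), and this step also held with either group on the carbonyl carbon: the same change on two cores in this assay, a 1.1-fold higher number (0.04 log units; within the scatter) from compound 1 to compound 3 and a 1.0-fold higher number (0.02 log units; within the scatter) from compound 2 to compound 4, 1.1-fold (0.02 log units) apart, within the scatter of two such steps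

This shows that the two changes acted independently across these four compounds, but it rests on a single pair of cores in one assay and does not show that the step would carry to other cores or explain why it holds.

The compounds shown leave open whether an amine or a carboxylic acid in place of bromo on that aromatic carbon would behave the same way. They also leave open how a phenyl bearing an amine on the carbonyl carbon would compare.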